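A methyl added to compound 2

A few compounds are considered here, and "the series" means these few. Any claim that something is new, unique, unknown or untested is made for them only; others in the source may bear on it.

Compound 1 `O=C(/C=C/c1cccnc1)NCCCCCCCc1ccc(S(=O)(=O)Nc2ccccc2)cc1`: 56.5 nM
Compound 2 `O=C(/C=C/c1cccnc1)NCCCCCCc1cccc(S(=O)(=O)Nc2ccccc2)c1`: 0.88 nM

In a functional assay on K562 cells (Homo sapiens) for inhibition, read by CCK-8 assay, with a stated time of 72 h (on this read-out lower numbers stand for stronger inhibition and higher numbers for weaker inhibition), compound 2 gives 0.88 nM, the lower of the two numbers. Compound 1 gives 56.5 nM, and this gap lies well beyond the usual scatter of repeated measurements. The two compounds differ in more than one place, so their values alone do not show what any single change does.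

The next compound to be tested, compound 3 `Cc1ccc(NS(=O)(=O)c2cccc(CCCCCCNC(=O)/C=C/c3cccnc3)c2)cc1`, keeps all of compound 2 except for one small edit: methyl in place of hydrogen on an aromatic carbon. In words, a methyl takes the place of a hydrogen on an aromatic carbon, turning the phenyl into 4-methylphenyl.

Among the measured compounds shown here, no measured pair here shows the effect of this edit, so the expectation is only a cautious one. Compound 2, at 0.88 nM, is the reference point, and a modest rise in the number seems more likely than a large shift in either direction. The expected change is a 1.7-fold higher number from compound 2 to compound 3 (0.23 log units; within the scatter), which may not clear the scatter. For compound 3 the estimated value is 1.5 nM, with an expected range from 0.4 nM to 6 nM.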

Compound 3, half-maximal inhibitory concentration: 2.98 nM
Compound 3: the middle estimate sits 2.0-fold (0.30 log units) below what was measured, and the stated range covers the measured number.
By their numbers in this assay, from the lowest: compound 2; then compound 3; then compound 1.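

Among the compounds shown here, compound 2 and compound 3 form the first pair here that differs in one place only, so a single edit can finally be read on its own: in this assay, turning the phenyl of the phenylsulfamoyl group into 4-methylphenyl gives a 3.4-fold higher number from compound 2 to compound 3 (0.53 log units; beyond the scatter). The change is modest yet beyond the scatter, so this position does respond to one added carbon, although inhibition is not lost, as compound 3 still gives 2.98 nM. No supporting measurement here explains why the number rises with this methyl.

On these data alone, it remains open whether a different group at this same place, such as a chloro, a methoxy or an amine, would raise the number further, leave it unchanged or lower it, and whether a methyl placed elsewhere on this ring would act in the same way. A single pair also cannot show whether the same methyl would have a similar effect on compound 1, whose chain and ring placement differ from those of compound 2.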